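From a Nitro Group to a Carboxy Group

The compounds below may be only part of what the source reports. "The series", "measured", "known", "first", "only" and "open" are said of these compounds alone.

Measured compounds:
compound 1, `c1ccc(COc2ccc(OCCOCCNc3cc[nH]c3)cc2)cc1` — 11300 nM
compound 2, `O=[N+]([O-])c1ccc(COc2ccc(OCCOCCNC3CCCC3)cc2)cc1` — 20300 nM
compound 3, `c1ccc(COc2ccc(OCCOCCNC3CC3)cc2)cc1` — 47200 nM

All three compounds share one core and were tested in a functional assay on SK-OV-3 cells (Homo sapiens) for inhibition, read by CCK-8 assay, with a stated time of 70 h; a higher number here means a weaker inhibitor, a lower number a stronger inhibitor. In this assay compound 2 gives 20300 nM, which lies within the usual scatter of compound 1 at 11300 nM, while the gap to compound 3 at 47200 nM is beyond the scatter. Among the compounds with values here, the one measured step, a 4.2-fold higher number from compound 1 to compound 3 (0.62 log units; beyond the scatter), is a modest change and concerns the group on the amine nitrogen.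

Compound 4, `O=C(O)c1ccc(COc2ccc(OCCOCCNC3CCCC3)cc2)cc1`, differs from compound 2 at a different place: carboxy in place of nitro on an aromatic carbon. Within the data shown here, no measured step touches this part of the molecule, so the step from compound 1 to compound 3 does not bear on it. With nothing to lean on, the expectation is that the step of a 1.0-fold lower number from compound 2 to compound 4 (0.01 log units; within the scatter) will be no larger than the scatter, in either direction. Compound 4 is therefore estimated at 20000 nM, with a range from 7000 nM to 60000 nM.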

Compound 4, half-maximal inhibitory concentration: > 100000 nM
Compound 4 ended at the assay's limit; the forecaster's own chance of this, stated with the estimate: 10%; middle value at least 5.0-fold (0.69 log units) away from the limit.
By their numbers in this assay, from the lowest: compounds 1 and 2 (each within the scatter of the next); then compound 3. At a limit, above all of these: compound 4.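

Nitro and carboxy bring the same number of heavy atoms to this aromatic carbon, para to a large group, yet the exchange is not silent: the data show an at least 4.9-fold higher number from compound 2 to compound 4 (0.69 log units; beyond the scatter). In this assay compound 4 gives > 100000 nM, which is a limit of the assay and not a number, so only the least size of the step is known. The earlier compounds varied only the group on the amine nitrogen, so this is the first sign that this end of the molecule matters, and the only further record concerns the limit itself: the limit of > 100000 nM in this assay, at which 1 of the 4 values shown sits.

From the compounds shown here alone, what a primary amide or a methyl ester would do at this place stays open. So does whether carboxy would have the same effect with another group on the amine nitrogen, such as the cyclopropyl of compound 3.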